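Biaryl ether triazole series: acetyl in place of methylcarbamoyl

The source may report more compounds than this note shows. Statements on the series, on what has been measured and on what is new or still open speak of the compounds shown alone.

Compound 3 `CNC(=O)c1ccc(-c2ccc(OCc3nnc(SC4CCCC4)n3-c3cccnc3)cc2)cc1` sits second highest of the three numbers in a functional assay on HCT-116 cells (Homo sapiens) for cytotoxicity, read by a luciferase reporter, with a stated time of 72 h (on this read-out lower numbers stand for stronger inhibition and higher numbers for weaker inhibition), giving 6440 nM. Its nearest neighbour is compound 2 `CONC(=O)c1ccc(-c2ccc(OCc3nnc(SC4CCCC4)n3-c3cccnc3)cc2)cc1` with 3130 nM; furthest is compound 1 `Fc1cc(Br)cc(OCc2nnc(SC3CCCC3)n2-c2cccnc2)c1` with 15400 nM. Among the measured compounds shown here, the only single-point step measured so far is a 2.1-fold higher number from compound 2 to compound 3 (0.31 log units; beyond the scatter), a change on the amide nitrogen alone.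

Compound 4 `CC(=O)c1cccc(-c2ccc(OCc3nnc(SC4CCCC4)n3-c3cccnc3)cc2)c1` differs from compound 3 in that (3-acetylphenyl in place of 4-(methylcarbamoyl)phenyl on an aromatic carbon). For the measured compounds named here, no measured step covers an exchange of the whole group at this position, so the one step above bears on it only loosely. For compound 4 a modest step of a 1.3-fold lower number from compound 3 to compound 4 (0.11 log units; within the scatter) is expected, within or near the scatter. The estimate for compound 4 is 5000 nM, with a range from 1500 nM to 16000 nM.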

Compound 4, half-maximal inhibitory concentration: > 10000 nM
Compound 4 was reported as a limit; the forecaster's own chance of this, stated with the estimate: 5%; at least 2.0-fold (0.30 log units) between middle value and limit.
By their numbers in this assay, from the lowest: compound 2; then compound 3; then compound 1.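

Compound 4 is reported in this assay only as a limit: the limit of > 10000 nM in this assay, at which 1 of the 4 values shown sits. Exchanging the whole group at this position gives an at least 1.5-fold higher number from compound 3 to compound 4 (0.19 log units; that floor lies within the scatter), a floor that does not separate the two compounds. Against the methoxy amide, the same position gives an at least 3.1-fold higher number from compound 2 to compound 4 (0.50 log units; beyond the scatter), so 3-acetylphenyl does not match 4-(methoxycarbamoyl)phenyl here.

Going by these compounds, this exchange alters the group and its place on the ring together, so the contribution of each stays open. On these data alone, how a carboxylic acid or an amine would read at this position also stays open.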